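This account rests on a few compounds, and the source may have more. Where it says the series, first, only, none or still open, it means among the compounds named here.

Measured in a functional assay on HeLa cells (Homo sapiens) for antiproliferative activity, read by MTT assay, with a stated time of 48 h; a higher number here means a weaker inhibitor, a lower number a stronger inhibitor:
- compound 1 `Cn1c(N)c(-c2nc3ccccc3[nH]2)c2nc(C#N)c(C#N)nc21`: > 50000 nM, a limit of the assay
- compound 2 `CN(C)CCn1c(N)c(-c2nc3ccccc3[nH]2)c2nc(C#N)c(C#N)nc21`: 8880 nM
- compound 3 `N#Cc1nc2c(-c3nc4ccccc4[nH]3)c(N)n(CCO)c2nc1C#N`: > 50000 nM, a limit of the assay

Compound 3 has no true number, only a limit. It sits at the limit of > 50000 nM in this assay, at which 2 of the 3 values shown sit.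

The next compound, compound 4 `CN(C)CCCn1c(N)c(-c2nc3ccccc3[nH]2)c2nc(C#N)c(C#N)nc21`, carries (dimethylamino)methyl in place of hydroxy on a saturated chain carbon, two bonds along the chain from an aromatic nitrogen. Cut one bond further out, this turns 2-hydroxyethyl into 3-(dimethylamino)propyl.

Among the measured compounds shown here, two measured steps bear on this change. The first is an at least 5.6-fold lower number from compound 1 to compound 2 (0.75 log units; beyond the scatter), and the second, which swaps dimethylamino for hydroxy, is an at least 5.6-fold higher number from compound 2 to compound 3 (0.75 log units; beyond the scatter). Only compound 2 gives a real number, 8880 nM, and compound 4 keeps its dimethylamino end on a longer chain. For the measured compounds named here, no measured compound shows what that extra length does, so the range stays wide.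

A lower number is expected, with the estimated change being an at least 5.5-fold lower number from compound 3 to compound 4 (0.74 log units; beyond the scatter). The estimate for compound 4 is 9000 nM, with an expected range from 2500 nM to 35000 nM.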

Compound 4, half-maximal inhibitory concentration: 25900 nM
Beside the measured number, compound 4's estimate is 2.9-fold (0.46 log units) below it; the measured number falls inside the stated range.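

In this assay, extending the chain that ends in dimethylamino weakens the compound, with a 2.9-fold higher number from compound 2 to compound 4 (0.46 log units; beyond the scatter), so the length of this chain matters and not only the presence of the amine. The other two comparisons say less, an at least 1.9-fold lower number from compound 3 to compound 4 (0.28 log units; that floor lies within the scatter) and an at least 1.9-fold lower number from compound 1 to compound 4 (0.28 log units; that floor lies within the scatter), and each starts from a limit of the assay, not a true number: the limit of > 50000 nM in this assay, at which 2 of the 4 values shown sit. Among the chains shown, only the shorter 2-(dimethylamino)ethyl chain of compound 2 clears the scatter at its floor against those limits.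

Two compounds on one side of a chain length cannot show whether a longer chain, such as 4-(dimethylamino)butyl, would weaken the compound further. Going by these compounds, it also stays open whether a different amine at the chain end, such as piperidine or morpholine, would behave like dimethylamino.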